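Trifluoromethyl for Fluoro on the Aryl Piperazine Ring

The source may report more compounds than this note shows. Statements on the series, on what has been measured and on what is new or still open speak of the compounds shown alone.

Measured compounds:
compound 1 `CCC(C(=O)N1CCN(c2cccc(F)c2)CC1)N1C(=O)CCC1=O`: 0%
compound 2 `CC(C(=O)N1CCN(c2ccccc2F)CC1)N1C(=O)CCC1=O`: 25%
compound 3 `CC(C(=O)N1CCN(c2ccccc2C(F)(F)F)CC1)N1C(=O)CCC1=O`: 75%

Of the compounds shown here, three have been tested in a functional assay on the whole organism (strain Swiss) with Mus musculus as the target, in the maximal electroshock model, with a stated time of 2 h, at a dose of 300 mg/kg by the intraperitoneal route; a lower number here means a weaker effect, a higher number a stronger effect of the compound at the dose given. Compound 1 gives 0%, the lowest of the three numbers. Compound 2 gives 25%, and compound 3 gives 75%. From compound 2 to compound 3 the change is trifluoromethyl in place of fluoro on an aromatic carbon, and it produced a number 50 percentage points higher from compound 2 to compound 3 (beyond the scatter).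

Compound 4 `CCC(C(=O)N1CCN(c2cccc(C(F)(F)F)c2)CC1)N1C(=O)CCC1=O` has not yet been measured in this assay. It arises from compound 1 by trifluoromethyl in place of fluoro on an aromatic carbon. Within the data shown here, this is the same kind of change as the one from compound 2 to compound 3, but not the same: in that pair the group sits ortho to a large group, whereas in compound 4 it sits meta to a large group. The difference between the core of compound 1 and the core of compound 2 is not broken down here.

Given that the earlier step was large and went upward, compound 4 is expected to show a number 30 percentage points higher from compound 1 to compound 4 (beyond the scatter) in this assay relative to compound 1, with wide uncertainty because compound 1 starts from 0%. Compound 4 is therefore estimated at 30%, between 0% and 65%.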

Compound 4, a percentage reported as activity, at one dose (the size of the read-out at that dose, not a potency): 50%
Beside the measured number, compound 4's estimate is 20 percentage points below it, within the range that was stated.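

In this assay, putting trifluoromethyl in place of fluoro on the core of compound 1 gave a number 50 percentage points higher from compound 1 to compound 4 (beyond the scatter), and this step matches the one seen on the other core: the same change on two cores in this assay, a number 50 percentage points higher (beyond the scatter) from compound 2 to compound 3 and a number 50 percentage points higher (beyond the scatter) from compound 1 to compound 4, 0 percentage points apart, within the scatter of two such steps In these two pairs, then, the change carried from one core to the other with its size intact. This does not make it a rule for the series, since two pairs are all there is, and they differ both in the core and in where the group sits, with compound 4 carrying it meta to a large group, so the contribution of each cannot be separated, nor does a reading at a single dose say anything about potency.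

The compounds shown leave open whether a chloro or methoxy group at the same place on the aromatic ring would give a step of similar size. They also leave open whether the step would survive on a core bearing a longer chain.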